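A few compounds are considered here, and "the series" means these few. Any claim that something is new, unique, unknown or untested is made for them only; others in the source may bear on it.

Working notes on the series. Compound 1 `Cc1nc(N(C)C(=O)NC(=O)c2c(F)cccc2F)sc1C(=O)N/N=C/c1ccc(C(F)(F)F)cc1`, compound 2 `CN(C(=O)NC(=O)c1ccccc1F)c1nc(C(F)(F)F)c(C(=O)N/N=C/c2ccc(C(F)(F)F)cc2)s1` and compound 3 `CN(C(=O)NC(=O)c1ccc([N+](=O)[O-])cc1)c1nc(C(F)(F)F)c(C(=O)N/N=C/c2cccc(C(F)(F)F)c2)s1` have been measured in a functional assay on MCF7 cells (Homo sapiens) for inhibition, read by MTT assay, with a stated time of 72 h; on this read-out higher numbers stand for weaker inhibition and lower numbers for stronger inhibition. Compound 1 gives 30.6 ug/mL, compound 2 gives 4.98 ug/mL and compound 3 gives 4.39 ug/mL. Compound 2 stands second highest of the three numbers: its nearest neighbour is compound 3, within the scatter, and its furthest is compound 1, beyond the scatter. Compound 4 `CN(C(=O)NC(=O)c1ccc(Cl)cc1Cl)c1nc(C(F)(F)F)c(C(=O)N/N=C/c2ccc(C(F)(F)F)cc2)s1` has not yet been measured in this assay. From compound 2 to compound 4 the change is 2,4-dichlorophenyl in place of 2-fluorophenyl on a carbonyl carbon. Among the compounds with values here, no measured pair in the set isolates this change, so its size is open. Compound 2 and compound 3, which differ from one another in more than one place, sit within the scatter of each other, and nothing in the measured set points to a step beyond the scatter in either direction for this replacement. Compound 4 is therefore expected to give about 4.5 ug/mL in this assay, with a range of 1.6 ug/mL to 13 ug/mL. The expected step of a 1.1-fold lower number from compound 2 to compound 4 (0.04 log units; within the scatter) is within the scatter.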

Compound 4, half-maximal inhibitory concentration: 8.42 ug/mL
Compound 4: middle estimate off by 1.9-fold (0.27 log units), on the low side; measured number inside the range.
By their numbers in this assay, from the lowest: compounds 3, 2 and 4 (each within the scatter of the next); then compound 1.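

In this assay, within the data shown here, this pair gives the first reading of a single change: a 1.7-fold higher number from compound 2 to compound 4 (0.23 log units; within the scatter), which stays within the scatter. On this carbonyl carbon, 2,4-dichlorophenyl and 2-fluorophenyl therefore cannot be told apart, even though the two groups differ in their halogen substituents, with two chlorine atoms entering and one fluorine leaving. No measured data are available to explain this result.

On these data alone, it remains open whether a group of another kind on this carbonyl carbon, such as a cyclohexyl ring or a 4-aminophenyl ring, would move the number beyond the scatter. This single pair also leaves open whether the same replacement would give a similar step on the core of compound 1 or compound 3.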